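The source may hold more compounds than are shown below. What is called first, only, known or untested is meant among the compounds shown, and "the series" means these compounds.

Measured compounds:
Compound 1, `COCC#Cc1cc(C(O)(C(F)(F)F)C(F)(F)F)cnc1N1CCN(S(=O)(=O)c2ccc(N)nc2)CC1`, gives 399 mL.min-1.g-1 in an ADME assay (liver) for metabolic stability, with Liver microsome (Rattus norvegicus) as the target, using microsomes and NADPH, with a stated time of 30 min, tested at 1 uM; on this read-out lower numbers stand for slow clearance and higher numbers for fast clearance.
Compound 2, `Nc1ccc(S(=O)(=O)N2CCN(c3ncc(C(O)(C(F)(F)F)C(F)(F)F)cc3-c3ccoc3)CC2)cn1`, gives 57 mL.min-1.g-1 in this assay.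
Compound 3, `Cc1ccc(-c2cc(C(O)(C(F)(F)F)C(F)(F)F)cnc2N2CCN(S(=O)(=O)c3ccc(N)nc3)CC2)cn1`, gives 182 mL.min-1.g-1 in this assay.

Among these three, compound 1 stands highest in this assay: the step to compound 3 is a 2.2-fold lower number from compound 1 to compound 3 (0.34 log units; beyond the scatter), and that to compound 2 is a 7.0-fold lower number from compound 1 to compound 2 (0.85 log units; beyond the scatter), both beyond the scatter. Compound 4, `COc1ccc(-c2cc(C(O)(C(F)(F)F)C(F)(F)F)cnc2N2CCN(S(=O)(=O)c3ccc(N)nc3)CC2)cn1`, has not been measured. It differs from compound 1 in one place: 6-methoxypyridin-3-yl in place of 3-methoxyprop-1-yn-1-yl on an aromatic carbon. For the measured compounds named here, two measured steps bear on this change, since each also puts an aromatic ring in place of 3-methoxyprop-1-yn-1-yl at the same carbon: a 7.0-fold lower number from compound 1 to compound 2 (0.85 log units; beyond the scatter) and a 2.2-fold lower number from compound 1 to compound 3 (0.34 log units; beyond the scatter). Both point downward by a modest amount, with the six-membered ring of compound 3 giving the smaller drop. Compound 4 carries a six-membered ring as well, so a modest downward step, beyond the scatter, is expected in this assay, roughly a 2.5-fold lower number from compound 1 to compound 4 (0.40 log units; beyond the scatter). Compound 4 is therefore estimated at 160 mL.min-1.g-1, with a likely range from 70 mL.min-1.g-1 to 350 mL.min-1.g-1.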

Compound 4, intrinsic clearance in microsomes: 265 mL.min-1.g-1
Compound 4: the middle estimate sits 1.7-fold (0.22 log units) below what was measured, within the range that was stated.
By their numbers in this assay, from the lowest: compound 2; then compounds 3, 4 and 1 (each within the scatter of the next, the first and the last beyond it).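

With 6-methoxypyridin-3-yl at this carbon, the number in this assay can no longer be told apart from that of the 3-methoxyprop-1-yn-1-yl group (a 1.5-fold lower number from compound 1 to compound 4 (0.18 log units; within the scatter)), so a six-membered aromatic ring here does not always give a step beyond the scatter, as compound 3 alone had suggested. On that ring, methoxy and methyl cannot be separated either (a 1.5-fold higher number from compound 3 to compound 4 (0.16 log units; within the scatter)). Among the four compounds, furan-3-yl remains the one group that stands clear of the rest, as the step to the methoxypyridine shows (a 4.6-fold higher number from compound 2 to compound 4 (0.67 log units; beyond the scatter)).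

As far as these compounds go, it remains open whether an amine, a carboxylic acid or a longer alkoxy chain on the pyridine ring would shift the number beyond the scatter. Nothing shown here explains why these groups give these numbers.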